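Swapping a sulfonyl-bearing ring for a difluoro ring

The compounds below may be only part of what the source reports. "The series", "measured", "known", "first", "only" and "open" are said of these compounds alone.

Measured compounds:
compound 1, `C[C@H](Nc1ncnc2[nH]cnc12)c1nn(-c2cccc(F)c2)c2cc(F)ccc12`, 28%
compound 2, `C[C@H](Nc1ncnc2[nH]cnc12)c1nn(-c2cccc(S(C)(=O)=O)c2)c2cc(F)ccc12`, 11%

In a functional assay on Hep 3B2 cells (Homo sapiens) for inhibition, read by sulforhodamine B assay, with a stated time of 72 h, tested at 10 uM (a lower number here means less inhibition, a higher number more inhibition at the concentration tested (going by the name of the read-out)), compound 1 gives 28%. In this assay compound 2 gives 11%, the lower of the two numbers shown, and the only measured step, a number 17 percentage points lower from compound 1 to compound 2 (beyond the scatter), shows that placing methylsulfonyl where fluoro had stood cost a modest amount of inhibition, beyond the scatter.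

Compound 3, `C[C@H](Nc1ncnc2[nH]cnc12)c1nn(-c2cc(F)cc(F)c2)c2cc(F)ccc12`, is the next step. It differs from compound 2 as follows: 3,5-difluorophenyl in place of 3-(methylsulfonyl)phenyl on an aromatic nitrogen. Among the measured compounds shown here, this change removes the methylsulfonyl-bearing ring that separates compound 2 from compound 1 and brings in a ring carrying two fluorines instead of one, so the step of a number 17 percentage points lower from compound 1 to compound 2 (beyond the scatter) is the one measured step that bears on it, taken in reverse. On that basis, compound 3 is expected to recover most of what compound 2 lost, with an estimated step of a number 15 percentage points higher from compound 2 to compound 3 (beyond the scatter) in this assay. For the measured compounds named here, compound 3 is therefore estimated at 26%, within a range from 10% to 42%, since only one measured step informs the expectation and the added second fluoro has no measured counterpart here.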

Compound 3, a percentage reported as inhibition, at one concentration (the size of the read-out at that concentration, not a potency): 14%
Beside the measured number, compound 3's estimate is 12 percentage points above it; the measured number falls inside the stated range.
By their numbers in this assay, from the lowest: compounds 2 and 3 (each within the scatter of the next); then compound 1.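

In this assay, putting 3,5-difluorophenyl in place of 3-(methylsulfonyl)phenyl on the aromatic nitrogen gives a number 3 percentage points higher from compound 2 to compound 3 (within the scatter), so this read-out does not separate these two rings, even though they share no substituent. The more informative comparison is with compound 1, where a single fluoro in place of hydrogen on an aromatic carbon gives a number 14 percentage points lower from compound 1 to compound 3 (beyond the scatter), showing that even this small edit to the ring can change the reading by more than the usual scatter; two quite different changes to compound 1 thus end within the scatter of each other. No measurement available here explains this shared outcome.

Still open, going by these compounds, is whether a ring with a methoxy group or an amine in place of the second fluoro would keep the inhibition seen with compound 1 or lose it as well. All of these readings also come from a single concentration, so they describe the size of the effect at that concentration and leave the potency of each compound undefined.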